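Diaryl methine in place of ethyl on a thiazole acetic acid

A few compounds are considered here, and "the series" means these few. Any claim that something is new, unique, unknown or untested is made for them only; others in the source may bear on it.

Measured compounds:
compound 1, `Nc1nc(-c2ccc(Cl)cc2)c(CC(=O)O)s1`, > 100000 nM
compound 2, `CCC(c1ccccc1)c1nc(-c2ccc(Cl)cc2)c(CC(=O)O)s1`, 190 nM
compound 3, `O=C(O)Cc1sc(Cc2ccccc2-c2ccccc2)nc1-c1ccc(Cl)cc1`, 41 nM

In an in vitro assay on HEK385-7 cells for displacement of a labelled ligand from prostaglandin D2 receptor 2 (Homo sapiens) (a higher number here means a weaker inhibitor, a lower number a stronger inhibitor), compound 1 gives only a limit, > 100000 nM, as one of the values sitting at the limit of > 100000 nM in this assay, at which 1 of the 3 values shown sits. Among the two numbers, compound 2 stands highest with 190 nM, while compound 3 gives the lower value, 41 nM, a gap beyond the usual scatter. Compound 4, `O=C(O)Cc1sc(C(c2ccccc2)c2ccccn2)nc1-c1ccc(Cl)cc1`, is not yet measured in this assay. It differs from compound 2 by pyridin-2-yl in place of ethyl on a saturated chain carbon bound to two aromatic carbons. Among the measured compounds shown here, no measured pair shows this same change, so the direction of the step is uncertain; compound 3, with two aromatic rings on the chain, gives the lower number of the two, which suggests a modest gain rather than a loss. Compound 4 is therefore expected to give about 100 nM, within roughly 30 nM to 400 nM, a step of a 1.9-fold lower number from compound 2 to compound 4 (0.28 log units; within the scatter).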

Compound 4, half-maximal inhibitory concentration: 810 nM
Estimate against measurement, compound 4: 8.1-fold (0.91 log units) below; measured number outside the range, above it.
By their numbers in this assay, from the lowest: compound 3; then compound 2; then compound 4. At a limit, above all of these: compound 1.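

In this assay, pyridin-2-yl in place of ethyl on a saturated chain carbon bound to two aromatic carbons gives a 4.3-fold higher number from compound 2 to compound 4 (0.63 log units; beyond the scatter). Among the compounds shown here, this position therefore responds to what it carries, and here the aromatic ring gives a weaker inhibitor than ethyl, a direction no earlier pair could show. Nothing measured here accounts for this step. The compounds shown leave open whether the loss follows from the ring itself or from its nitrogen, which a phenyl at this place would separate. A methyl there would show whether a shorter chain holds the number of compound 2.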